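The source may report more compounds than this note shows. Statements on the series, on what has been measured and on what is new or still open speak of the compounds shown alone.

Compound 1 `C=CC(=O)Oc1cc(C(F)(F)F)cc(C(F)(F)F)c1` and compound 2 `O=C(CBr)c1cc(C(F)(F)F)cc(C(F)(F)F)c1` were examined in an ADME assay for pharmacokinetics, read by LC-MS, in phosphate buffer, with a stated time of 72 h, at pH 7.4, tested at 250 uM; a lower number here means that the compound disappears faster, a higher number that the compound lasts longer. In this assay compound 1 gives < 0.017 h, which is a limit of the assay rather than a number. Compound 2 likewise gives < 0.017 h, again a limit and not a number. Among the measured compounds shown here, the one measured step, a step that the two limits leave unreadable from compound 1 to compound 2, therefore has no readable size, because of the limit of < 0.017 h in this assay, at which 2 of the 2 values shown sit. Compound 2 thus stands at the floor of what this assay reports, with no number of its own to place it more finely. Compound 3 `Fc1cc(C(F)(F)F)cc(C(F)(F)F)c1` differs from it by fluoro in place of (bromomethyl)carbonyl on an aromatic carbon. For the measured compounds named here, no measured step bears on this change in a readable way, since the only one available runs between two limits. The expectation for compound 3 in this assay is nonetheless a long half-life, quite possibly itself reported only as a limit, and the expected step is an at least 29000-fold higher number from compound 2 to compound 3 (4.46 log units; beyond the scatter). Compound 3 is estimated at 500 h, in a range from 50 h to 5000 h.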

Compound 3, half-life: > 50 h
Compound 3: only a limit was reported (the forecaster's own chance of this, stated with the estimate: 90%); the middle value does not contradict the limit.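

Fluoro on this aromatic carbon, meta to two trifluoromethyl groups, gives the first steps at this position that can be read in this assay. Fluoro in place of (bromomethyl)carbonyl gives an at least 2900-fold higher number from compound 2 to compound 3 (3.46 log units; beyond the scatter), and fluoro in place of (vinylcarbonyl)oxy gives an at least 2900-fold higher number from compound 1 to compound 3 (3.46 log units; beyond the scatter), both of them steps between limits and not between numbers. The step between compound 1 and compound 2 still cannot be read: the limit of < 0.017 h in this assay, at which 2 of the 3 values shown sit.

The compounds shown leave open where an amine, a carboxylic acid or a plain methyl group at this position would fall between these limits. They also leave open which part of the (bromomethyl)carbonyl or (vinylcarbonyl)oxy group accounts for the steps, since each group leaves as a whole.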